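A few compounds are considered here, and "the series" means these few. Any claim that something is new, unique, unknown or untested is made for them only; others in the source may bear on it.

Measured in a functional assay on IGROV-1 cells (Homo sapiens) for inhibition; on this read-out lower numbers stand for stronger inhibition of growth and higher numbers for weaker inhibition of growth:
- compound 1 `Nc1ccc(-c2nc3ccc(F)cc3s2)cc1I`: < 10 nM (a limit)
- compound 2 `Cc1cc(-c2nc3cccc(F)c3s2)ccc1N`: 70 nM
- compound 3 `Nc1ccc(-c2nc3cc(F)ccc3s2)cc1Br`: < 10 nM (a limit)

Going by the values given here, compound 2 gives the only actual number here. Compound 1 and compound 3 stand at the limit of < 10 nM in this assay, at which 2 of the 3 values shown sit.

Compound 4 `Cc1cc(-c2nc3ccccc3s2)ccc1N` carries hydrogen in place of fluoro on an aromatic carbon. Among the compounds with values here, no measured pair isolates this change. Compound 2 gives 70 nM, and this one value alone supports the expectation that follows. A moderate change toward stronger inhibition is expected in this assay, with an estimated step of a 3.5-fold lower number from compound 2 to compound 4 (0.54 log units; beyond the scatter). For compound 4 the estimated value is 20 nM, with an expected range of 5 nM to 70 nM.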

Compound 4, concentration for 50% growth inhibition: < 10 nM
Compound 4 ended at the assay's limit (the forecaster's own chance of this, stated with the estimate: 45%); middle value at least 2.0-fold (0.30 log units) from the limit.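

In this assay, going by these compounds alone, replacing fluoro with hydrogen on this aromatic carbon gives the first one-place comparison: an at least 7.0-fold lower number from compound 2 to compound 4 (0.84 log units; beyond the scatter). Compound 4 stands at a limit, < 10 nM, not at a number, so the step fixes only a minimum size. Fluoro at this position is therefore not required for strong inhibition of growth, and hydrogen gives the lower number here.

As far as these compounds go, the full size of the step stays open, with the values crowded at one end of the read-out: the limit of < 10 nM in this assay, at which 3 of the 4 values shown sit. From the compounds shown here alone, whether a methoxy group or an amine on this carbon would hold that level also remains open.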